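Adding a fluoro group to compound 2

A few compounds are considered here, and "the series" means these few. Any claim that something is new, unique, unknown or untested is made for them only; others in the source may bear on it.

Among the compounds with values here, in an ADME assay on L929 cells (Mus musculus) for cytotoxicity, read by resazurin assay, with a stated time of 96 h (a higher number here means that more compound is tolerated, a lower number that less compound is tolerated), compound 2 `NC(=S)N/N=C(\COc1ccccc1)c1ccc(Br)cc1` gives 54900 nM and stands level with compound 3 `COc1cccc(OC/C(=N\NC(N)=S)c2ccc(Br)cc2)c1` at 50700 nM among the numbers measured so far. Compound 1 `NC(=S)N/N=C(/COc1ccc(Br)cc1)c1ccc(Cl)cc1` gives 25100 nM as a lower number than compound 2 shows, but the two differ in more than one place, so this gap is no clean guide.

Compound 4 `NC(=S)N/N=C(\COc1ccc(F)cc1)c1ccc(Br)cc1` differs from compound 2 by a single swap fluoro in place of hydrogen on an aromatic carbon that puts fluoro in place of hydrogen on an aromatic carbon. Within the data shown here, only one measured step bears on this, methoxy in place of hydrogen on an aromatic carbon, which gave a 1.1-fold lower number from compound 2 to compound 3 (0.03 log units; within the scatter) and so stayed within the scatter. Methoxy is not fluoro and one step is thin evidence, yet it offers no reason to expect a large shift in this assay here. The estimated change is a 1.1-fold lower number from compound 2 to compound 4 (0.04 log units; within the scatter) and no direction is expected beyond the scatter. Thus compound 4 is estimated at 50000 nM with 28000 nM to 90000 nM as the expected range of a measurement.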

Compound 4, half-maximal cytotoxic concentration: 52300 nM
The estimate for compound 4 lay 1.0-fold (0.02 log units) below the measured number; the measured number falls inside the stated range.
By their numbers in this assay, from the lowest: compound 1; then compounds 3, 4 and 2 (each within the scatter of the next).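

In this assay, fluoro in place of hydrogen on an aromatic carbon, para to a large group, leaves the number within the scatter (a 1.0-fold lower number from compound 2 to compound 4 (0.02 log units; within the scatter)). Within the data shown here, the only earlier single change on this ring was methoxy (a 1.1-fold lower number from compound 2 to compound 3 (0.03 log units; within the scatter)), so a second, quite different group has now also produced no readable shift, although the two groups do not sit at the same place. Nothing measured here explains why the number holds steady under these two changes. As far as these compounds go, whether an amine or a carboxylic acid at the same place would move the number remains open. Also open, from the compounds shown here alone, is what sets compound 1 (25100 nM) apart, since it differs from compound 2 in more than one place and no single change can be singled out.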